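Swapping an octyl chain for a chlorophenoxy group

The compounds below may be only part of what the source reports. "The series", "measured", "known", "first", "only" and "open" are said of these compounds alone.

Of the compounds shown here, two have been measured in a physicochemical assay for lipophilicity, read by HPLC, tested at 5 mM; on this read-out higher numbers stand for higher lipophilicity and lower numbers for lower lipophilicity. Compound 1, `CC(Oc1ccc(Oc2ccc(Cl)cc2)cc1)C(=O)Cn1nnc(-c2ccc(Cl)cc2)n1`, carries a 4-chlorophenoxy group and in this assay compound 1 gives 6.8. Compound 2, `CCCCCCCCc1ccc(OC(C)C(=O)Cn2nnc(-c3ccc(C(=O)OC)cc3)n2)cc1`, carries an octyl chain instead. For compound 2 the read-out in this assay is only a limit of the assay, > 8, and not a number. This is the limit (the limit of > 8 in this assay, at which 1 of the 2 values shown sits). Within the data shown here, the two compounds also differ in the group on the other aromatic ring, so no single step between them is defined.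

Compound 3, `COC(=O)c1ccc(-c2nnn(CC(=O)C(C)Oc3ccc(Oc4ccc(Cl)cc4)cc3)n2)cc1`, has not yet been measured. It keeps the methyl ester end of compound 2 but changes the chain end: 4-chlorophenoxy in place of octyl on an aromatic carbon. Since compound 2 sits at a limit, the step cannot be read from a shown pair. Compound 1, which carries the same 4-chlorophenoxy group, gives 6.8 in this assay, and this is what the expectation for compound 3 rests on. For compound 3 the step in this assay is estimated as a number at least 1.70 log units lower from compound 2 to compound 3 (beyond the scatter), downward and beyond the scatter. For compound 3 the expected value in this assay is 6.3, with a range from 5.5 to 7.2.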

Compound 3, partition coefficient: 6.1
Compound 3: the middle estimate sits 0.20 log units above what was measured; low and high end bracket the measured number.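

Among these compounds, with the methyl ester end held, the change from octyl to 4-chlorophenoxy on an aromatic carbon gives the first step that can be read at this position in this assay: a number at least 1.90 log units lower from compound 2 to compound 3 (beyond the scatter). Compound 2 stands at a limit of the assay and not at a number, so this step gives only a bound and not its full size: the limit of > 8 in this assay, at which 1 of the 3 values shown sits. Compound 3 also opens a second comparison, at the other end of the molecule, where 4-chlorophenoxy stays in place and methoxycarbonyl replaces chloro on an aromatic carbon, giving a number 0.70 log units lower from compound 1 to compound 3 (beyond the scatter).

The compounds shown do not tell how far the read-out would move with a shorter chain such as hexyl in place of octyl, which might bring the value inside the range of the assay and turn the bound into a number. They also leave open how a carboxylic acid or an amine in place of methoxycarbonyl or chloro on that aromatic ring would read in this assay.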